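Varying the unsaturated acyl chain on a trimethoxyphenyl amide

This account rests on a few compounds, and the source may have more. Where it says the series, first, only, none or still open, it means among the compounds named here.

Compound 1 `COc1ccc(CNc2cc(OC)c(OC)c(OC)c2)cc1`: 4890 nM
Compound 2 `COc1cc(NCc2ccccc2)cc(OC)c1OC`: > 80000 nM
Compound 3 `COc1ccc(CN(C(=O)C=C(C)C)c2cc(OC)c(OC)c(OC)c2)cc1O`: 280 nM

Three compounds share a trimethoxyphenyl core carrying a benzylamine arm and have been measured in a functional assay on KYSE-450 cells (Homo sapiens) for inhibition, read by MTT assay, with a stated time of 48 h; a higher number here means a weaker inhibitor, a lower number a stronger inhibitor. Compound 1 `COc1ccc(CNc2cc(OC)c(OC)c(OC)c2)cc1` gives 4890 nM. Compound 2 `COc1cc(NCc2ccccc2)cc(OC)c1OC` reaches only the limit of this assay, > 80000 nM, so no number is known for it; it sits at the limit of > 80000 nM in this assay, at which 1 of the 3 values shown sits. For the measured compounds named here, the one measured step, an at least 16-fold higher number from compound 1 to compound 2 (1.21 log units; beyond the scatter), is a large one. Compound 3 `COc1ccc(CN(C(=O)C=C(C)C)c2cc(OC)c(OC)c(OC)c2)cc1O` gives 280 nM in this assay and stands at the lower of the two numbers, with compound 1 higher by a margin beyond the scatter.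

Compound 4 `CC/C=C/C(=O)N(Cc1ccc(OC)c(O)c1)c1cc(OC)c(OC)c(OC)c1` has not been measured. It differs from compound 3 by but-1-en-1-yl in place of 2-methylprop-1-en-1-yl on a carbonyl carbon. Going by the values given here, no measured step touches this part of the molecule: the step from compound 1 to compound 2 concerns a methoxy on an aromatic carbon, not the acyl chain. With no evidence of a shift in either direction, compound 4 is expected to stay within the scatter of compound 3, a 1.1-fold higher number from compound 3 to compound 4 (0.03 log units; within the scatter). Compound 4 is therefore estimated at 300 nM, between 120 nM and 800 nM.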

Compound 4, half-maximal inhibitory concentration: 72 nM
Beside the measured number, compound 4's estimate is 4.2-fold (0.62 log units) above it; measured number below the stated range.
By their numbers in this assay, from the lowest: compound 4; then compound 3; then compound 1. At a limit, above all of these: compound 2.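

Moving from 2-methylprop-1-en-1-yl to but-1-en-1-yl on the carbonyl carbon gives a 3.9-fold lower number from compound 3 to compound 4 (0.59 log units; beyond the scatter) in this assay, so this position responds to the change and is not a silent part of the molecule. The two chains match in every count given for them, so a different arrangement of the same carbon atoms is enough to move the number, which the earlier step, confined to a methoxy on an aromatic carbon, could not show. Nothing measured here bears on what lies behind this step.

Going by these compounds, it remains open how a saturated butyl chain, a longer chain or a chain ending in an amine or a carboxylic acid would read at this position. Also open, on these data alone, is whether a phenyl group on the carbonyl carbon would keep a number in this range.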